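The source may hold more compounds than are shown below. What is called first, only, known or untested is meant among the compounds shown, and "the series" means these compounds.

Measured compounds: compound 1 `O=C(O)CCCc1cn(CC(=O)O)c2c(/C=C/c3ccc(OCCCCc4c(F)ccc(F)c4F)cc3)cccc12` gives 1.4 10^-6 cm/s; compound 2 `Cc1c(CCCC(=O)O)c2cccc(/C=C/c3ccc(OCCCCc4ccccc4)cc3)c2n1CC(=O)O` gives 1.3 10^-6 cm/s; compound 3 `Cc1c(CCCC(=O)O)c2cccc(/C=C/c3ccc(OCCCCc4c(F)cc(F)c(F)c4F)cc3)c2n1CC(=O)O` gives 2.9 10^-6 cm/s.

In a physicochemical assay for permeability, using PAMPA, with a stated time of 4 h, at pH 6.2, tested at 50 uM (on this read-out higher numbers stand for higher permeability and lower numbers for lower permeability), compound 1 stands second highest of the three: its number and that of compound 2 lie within the scatter of each other, while compound 3 sits clearly above it. Compound 4 `Cc1c(F)cccc1CCCCOc1ccc(/C=C/c2cccc3c(CCCC(=O)O)cn(CC(=O)O)c23)cc1` is not yet measured. It differs from compound 1 in one place: 3-fluoro-2-methylphenyl in place of 2,3,6-trifluorophenyl on a saturated chain carbon, four bonds along the chain from an oxygen on an aromatic ring. For the measured compounds named here, only one measured step bears on this change, a 2.2-fold higher number from compound 2 to compound 3 (0.35 log units; beyond the scatter), where adding four fluorines to the phenyl ring at the same place raised the number modestly. The change to compound 4 runs partly the other way, removing two fluorines and bringing in a methyl, so a step of at most similar size, pointing downward or staying within the scatter, is expected. The estimate for compound 4 is 1.2 10^-6 cm/s, with a range from 0.6 10^-6 cm/s to 2.4 10^-6 cm/s. This estimate means an expected step of a 1.2-fold lower number from compound 1 to compound 4 (0.07 log units; within the scatter).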

Compound 4, apparent permeability: 3.5 10^-6 cm/s
Compound 4: middle estimate off by 2.9-fold (0.46 log units), on the low side, and the stated range ends below it.
By their numbers in this assay, from the lowest: compounds 2 and 1 (each within the scatter of the next); then compounds 3 and 4 (each within the scatter of the next).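

In this assay this change at the chain end gives a 2.5-fold higher number from compound 1 to compound 4 (0.40 log units; beyond the scatter) on the shared core, even though the entering ring carries fewer fluorines than the one it replaces. The earlier step, a 2.2-fold higher number from compound 2 to compound 3 (0.35 log units; beyond the scatter) on a different core, came with fluorines added, so the fluorine count on this ring does not by itself set the direction of the number. Nothing shown here explains why the number moves this way.

Because a methyl enters as fluorines leave in one single change, the compounds shown cannot tell which of the two carries the step. Also open, on these data alone, is how the number would respond to a chlorine or a methoxy group on this ring, or to a longer chain, on the core of compound 1.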